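This account rests on a few compounds, and the source may have more. Where it says the series, first, only, none or still open, it means among the compounds named here.

Series notes, cytotoxicity on macrophage cells.

Compound 1 `O=S(=O)(Nc1nccc2ccccc12)c1ccc(Cl)cc1` carries a 4-chlorophenyl sulfonamide on one core; compound 2 `O=S(=O)(Nc1nccc2ccccc12)c1ccccc1` is the same core with phenyl in its place. Compound 3 `Cc1cc2cc(NS(=O)(=O)c3ccc(Cl)cc3)ccc2[nH]1` carries the 4-chlorophenyl sulfonamide on a second core; the difference between the two cores is not broken down here. Compound 4 `Cc1cc2cc(NS(=O)(=O)c3ccccc3)ccc2[nH]1` is compound 3 with phenyl.

In an ADME assay on J774 cells (Mus musculus) for cytotoxicity, read by fluorescence and resazurin assay, with a stated time of 24 h (on this read-out lower numbers stand for higher toxicity in this test and higher numbers for lower toxicity in this test), compound 1 sits at a limit of the assay, >= 300000 nM. In this assay compound 2 likewise sits at a limit, >= 300000 nM. The change hydrogen in place of chloro on an aromatic carbon therefore gives a step that the two limits leave unreadable from compound 1 to compound 2; the two limits leave the size unreadable, and this is shown by the limit of >= 300000 nM in this assay, at which 2 of the 3 values shown sit. In this assay, within the data shown here, compound 3 gives 195000 nM, the only number among the three values.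

The change from compound 3 to compound 4 is the same one, (hydrogen in place of chloro on an aromatic carbon), with the place described in identical words. Among the measured compounds shown here, the only measured instance of it is unreadable, so there is no measured step to lean on. The expectation is that compound 4 stays close to compound 3, since the step in compound 1 to compound 2 showed no readable movement, and the expected step is a 1.2-fold higher number from compound 3 to compound 4 (0.07 log units; within the scatter). For compound 4 in this assay the estimate is 230000 nM, expected between 110000 nM and 300000 nM, with a real chance that only a limit is reported.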

Compound 4, half-maximal cytotoxic concentration: >= 300000 nM
Compound 4 ended at the assay's limit; the forecaster's own chance of this, stated with the estimate: 40%; middle value at least 1.3-fold (0.11 log units) from the limit.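

On the core of compound 3, the change of 4-chlorophenyl to phenyl gives an at least 1.5-fold higher number from compound 3 to compound 4 (0.18 log units; that floor lies within the scatter) in this assay; the value of compound 4 is a limit of the assay, so this step is a floor and not a measured size. The steps on the core of compound 1 and on the core of compound 3 therefore cannot be set side by side: the first cannot be read at all, and the second has only a lower bound, so the data show no reversal of direction between the cores but do not show that the change has the same size on both. The reach of this comparison is capped by the top of the assay's range, and the series offers little room to tell the two cores apart on this change: the limit of >= 300000 nM in this assay, at which 3 of the 4 values shown sit.

The compounds shown leave open whether any replacement on this aromatic carbon, such as an amine, a carboxylic acid or a longer alkyl chain, would bring either core to a readable number in this assay. They also leave open whether a pair with readable values at both ends would show the change from 4-chlorophenyl to phenyl acting alike on the two cores.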